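A few compounds are considered here, and "the series" means these few. Any claim that something is new, unique, unknown or untested is made for them only; others in the source may bear on it.

Compounds measured so far:
compound 1, `CC(=O)Nc1nc(N)nc2c1ncn2[C@H]1CO[C@@H](CO)O1`, > 100000 nM
compound 2, `CCCC(=O)Nc1nc(N)nc2c1ncn2[C@H]1CO[C@@H](CO)O1`, > 100000 nM

In a functional assay on HepG2 cells (Homo sapiens) for cytotoxicity (on this read-out higher numbers stand for lower toxicity in this test and lower numbers for higher toxicity in this test), compound 1 gives > 100000 nM, which is a limit of the assay rather than a number. Compound 2 gives > 100000 nM, likewise a limit. So compound 1 stands only at a limit, as does the one other value shown, and the single measured step, a step that the two limits leave unreadable from compound 1 to compound 2, cannot be read in size or direction, since (the limit of > 100000 nM in this assay, at which 2 of the 2 values shown sit).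

Compound 3, `CCCCCCCCCCCC(=O)Nc1nc(N)nc2c1ncn2[C@H]1CO[C@@H](CO)O1`, differs from compound 1 by decyl in place of hydrogen on a saturated chain carbon bound to a carbonyl carbon. The measured step does bear on this change, as it also lengthens the chain on the same carbon, but its size is unreadable, so no step beyond the scatter can be read from it in this assay. Compound 3 is therefore expected to give 90000 nM (between 25000 nM and 300000 nM). The expected step is an at least 1.1-fold lower number from compound 1 to compound 3 (0.04 log units; that floor lies within the scatter).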

Compound 3, half-maximal cytotoxic concentration: > 100000 nM
Compound 3 gave a limit, no number; the forecaster's own chance of this, stated with the estimate: 55%; middle value at least 1.1-fold (0.04 log units) from the limit.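

Compound 3, like compound 1 and compound 2, gives only a limit in this assay, so no step among these three compounds can be read: the limit of > 100000 nM in this assay, at which 3 of the 3 values shown sit. The compounds shown leave open whether the chain on the shared core changes the result in this assay at all.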